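Swapping Benzylamino for a Methylpiperazine on the Shared Core

The source may hold more compounds than are shown below. What is called first, only, known or untested is meant among the compounds shown, and "the series" means these compounds.

Compound 1 `Cc1ccc(NC(=O)Nc2ccc(Oc3cc(NCc4ccccc4)ncn3)cc2)cc1C(F)(F)F` in a functional assay on BaF3 cells (Mus musculus) for inhibition, read by CCK-8 assay, with a stated time of 72 h (on this read-out lower numbers stand for stronger inhibition of growth and higher numbers for weaker inhibition of growth), gives 3010 nM, the lowest of the two numbers shown. Compound 2 `Cc1ccc(NC(=O)Nc2ccc(Oc3cc(/N=C/N(C)C)ncn3)cc2)cc1C(F)(F)F` gives 6610 nM, a step of a 2.2-fold higher number from compound 1 to compound 2 (0.34 log units; beyond the scatter). Compound 3 `Cc1ccc(NC(=O)Nc2ccc(Oc3cc(NCCN)ncn3)cc2)cc1C(F)(F)F` reaches only the assay limit of > 10000 nM. From compound 1 to compound 3 the step is an at least 3.3-fold higher number from compound 1 to compound 3 (0.52 log units; beyond the scatter). Compound 4 `Cc1ccc(NC(=O)Nc2ccc(Oc3cc(N4CCN[C@H](C)C4)ncn3)cc2)cc1C(F)(F)F` differs from compound 1 by 3-methylpiperazin-1-yl in place of benzylamino on an aromatic carbon. Both measured steps away from benzylamino raised the number, so a higher number is also expected for compound 4, in the region of a 2.7-fold higher number from compound 1 to compound 4 (0.42 log units; beyond the scatter). Compound 4 is therefore estimated at 8000 nM, with a range from 3000 nM to 20000 nM.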

Compound 4, concentration for 50% growth inhibition: 8920 nM
Compound 4: middle estimate off by 1.1-fold (0.05 log units), on the low side; the range from low to high includes it.
By their numbers in this assay, from the lowest: compound 1; then compounds 2 and 4 (each within the scatter of the next). At a limit, above all of these: compound 3.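

Replacing benzylamino with the ring 3-methylpiperazin-1-yl also weakens growth inhibition, with a 3.0-fold higher number from compound 1 to compound 4 (0.47 log units; beyond the scatter), so a non-aromatic ring at this position joins the open-chain groups on the weaker side of compound 1. No separation is seen in the next step, a 1.3-fold higher number from compound 2 to compound 4 (0.13 log units; within the scatter). Compound 3 sits at a limit of the assay: the limit of > 10000 nM in this assay, at which 1 of the 4 values shown sits. The remaining step, an at least 1.1-fold lower number from compound 3 to compound 4 (0.04 log units; that floor lies within the scatter), rests on that limit and cannot be read as a difference.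

Still open, as far as these compounds go, is whether the aromatic ring of benzylamino itself matters, which a cyclohexylmethylamino group or a longer phenethylamino chain could test. Plain piperazin-1-yl could likewise test what the methyl group contributes.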